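A few compounds are considered here, and "the series" means these few. Any claim that something is new, unique, unknown or untested is made for them only; others in the source may bear on it.

Within the data shown here, in a functional assay on A549 cells (Homo sapiens) for antiproliferative activity, read by MTT assay, with a stated time of 72 h (on this read-out higher numbers stand for weaker inhibition and lower numbers for stronger inhibition), compound 2 `CN1CCN(c2ccc(Nc3ncc4nc(Nc5ccc(F)cc5)n(-c5cccc(NC(=O)CO)c5)c4n3)cc2)CC1` gives 1510 nM, and that is the only number to hand. Compound 1 `CN1CCN(c2ccc(Nc3ncc4nc(Nc5ccc(F)cc5)n([C@@H]5CCN(C(=O)CO)C5)c4n3)cc2)CC1`, which shares the same core, carries no result in this assay and its entry reads "not determined" (no result reported), so compound 2 stands alone on the measured side with nothing to rank it against. Compound 3 `CN1CCN(c2ccc(Nc3ncc4nc(Nc5ccc(F)cc5)n([C@@H]5CCN(S(=O)(=O)C6CC6)C5)c4n3)cc2)CC1` differs from compound 2 in a single place: 1-(cyclopropylsulfonyl)pyrrolidin-3-yl in place of 3-(((hydroxymethyl)carbonyl)amino)phenyl on an aromatic nitrogen. Among the measured compounds shown here, no step between two measured compounds is available to show how a change of this kind moves this assay, so any expectation rests on the starting value of compound 2 alone. The expected step, a 1.5-fold lower number from compound 2 to compound 3 (0.18 log units; within the scatter), is small, points in no firm direction, and may well stay within the usual scatter. On that basis compound 3 is estimated to give about 1000 nM in this assay, with a range from 200 nM to 5000 nM.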

Compound 3, half-maximal inhibitory concentration: > 10000 nM
Compound 3: only a limit was reported; the forecaster's own chance of this, stated with the estimate: 10%; middle value at least 10-fold (1.00 log units) away from the limit.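

In this assay, among these compounds, the group on this aromatic nitrogen clearly matters, a point no earlier compound could show: swapping it gives an at least 6.6-fold higher number from compound 2 to compound 3 (0.82 log units; beyond the scatter), and a higher number here means weaker inhibition. The swap changes several features at once, as an aromatic carbon ring gives way to a five-membered non-aromatic ring carrying a cyclopropylsulfonyl group, and the entering group has no hydrogen-bond donors. The figure for compound 3 is a limit of the assay, not a number: the limit of > 10000 nM in this assay, at which 1 of the 3 values shown sits.

Among the compounds shown here, the single step cannot tell which of these features matters, and compound 1, which keeps the hydroxyacetyl-type amide on a pyrrolidine ring, reads "not determined" (no result reported) and cannot separate them. On these data alone, whether a plain phenyl or a pyrrolidin-3-yl with a free ring amine would behave like compound 2 or compound 3 remains open.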